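Fluoro for chloro on the benzyl of compound 1

A few compounds are considered here, and "the series" means these few. Any claim that something is new, unique, unknown or untested is made for them only; others in the source may bear on it.

Compound 1 `CCOC(=O)C1=C(C(=O)OCC)C2CSC(CS1)N2Cc1ccc(Cl)cc1` was tested in an ADME assay on J774 cells (Mus musculus) for cytotoxicity, read by WST assay, with a stated time of 24 h (on this read-out higher numbers stand for an effect only at larger amounts of compound and lower numbers for an effect already at smaller amounts), and compound 1 gives only a limit there, > 200000 nM. That reading is the limit of > 200000 nM in this assay, at which 1 of the 2 values shown sits. For the measured compounds named here, compound 2 `O=C(OCc1c(-c2ccccc2)no[n+]1[O-])C1=C(C(=O)c2ccc(Cl)cc2)C2CSC(CS1)N2Cc1ccccc1` is the other compound measured so far, and in this assay compound 2 gives 3100 nM. Compound 3 `CCOC(=O)C1=C(C(=O)OCC)C2CSC(CS1)N2Cc1ccc(F)cc1` has not yet been measured in this assay. Compound 3 differs from compound 1 in one place: fluoro in place of chloro on an aromatic carbon. Going by the values given here, no measured pair shows this change, so its size in this assay is unknown; the account expects no step beyond the usual scatter, and nothing among the measured values points in either direction. Compound 3 is therefore expected to sit at 200000 nM, within a range from 100000 nM to 400000 nM, and most likely again as a limit. The expected step from compound 1 to compound 3 is a number no higher from compound 1 to compound 3 (the limit leaves the size open).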

Compound 3, half-maximal effective concentration: 64400 nM
Compound 3: middle estimate off by 3.1-fold (0.49 log units), on the high side, outside the stated range (below it).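

Fluoro in place of chloro, on the six-membered aromatic ring and para to a large group, is not a silent change in this assay: the swap gives an at least 3.1-fold lower number from compound 1 to compound 3 (0.49 log units; beyond the scatter). For the compounds shown here, this is the first evidence that the read-out responds to a single halogen exchange at this position, something compound 2, which differs from compound 1 in more than one place, could not show. The step is only a lower bound because compound 1 stands at a limit of the assay: the limit of > 200000 nM in this assay, at which 1 of the 3 values shown sits.

Going by these compounds, the full size of the step remains open, and this single pair cannot show whether it would recur on another scaffold. On these data alone, how a methoxy, an amine or a carboxylic acid at this position would read also remains open.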